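Chloro Substitution in Two Related Thiazolylidene Hydrazides

The source may hold more compounds than are shown below. What is called first, only, known or untested is meant among the compounds shown, and "the series" means these compounds.

Of the compounds shown here, three have been measured in an ADME assay on NIH3T3 cells (Mus musculus) for cytotoxicity, read by MTT assay, with a stated time of 24 h; a lower number here means a stronger inhibitor, a higher number a weaker inhibitor. Compound 3 `O=C(CSc1nnnn1-c1ccccc1)N/N=c1/scc(-c2ccccc2)n1-c1ccccc1` gives 417 ug/mL. Compound 1 `O=C(CSc1nnnn1-c1ccccc1)N/N=c1/scc(-c2ccc(Cl)cc2)n1-c1ccccc1` gives 313 ug/mL; it differs from compound 3 by chloro in place of hydrogen on an aromatic carbon, and the step of a 1.3-fold lower number from compound 3 to compound 1 (0.12 log units; within the scatter). Compound 2 `Cn1cnnc1SCC(=O)N/N=c1/scc(-c2ccccc2)n1-c1ccccc1` gives 217 ug/mL; its core differs from that of compound 3 by 4-methyl-4H-1,2,4-triazol-3-yl in place of 1-phenyl-1H-tetrazol-5-yl on a sulfur, and the step of a 1.9-fold higher number from compound 2 to compound 3 (0.28 log units; within the scatter). Compound 4 `Cn1cnnc1SCC(=O)N/N=c1/scc(-c2ccc(Cl)cc2)n1-c1ccccc1` has not yet been measured. It differs from compound 2 by chloro in place of hydrogen on an aromatic carbon, which is the same change as that from compound 3 to compound 1, on a different core. Because the measured step of a 1.3-fold lower number from compound 3 to compound 1 (0.12 log units; within the scatter) stayed within the scatter, the corresponding step from compound 2 to compound 4 is expected to be small, about a 1.2-fold lower number from compound 2 to compound 4 (0.09 log units; within the scatter). Compound 4 is therefore estimated at 175 ug/mL, between 90 ug/mL and 340 ug/mL.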

Compound 4, half-maximal inhibitory concentration: 51.7 ug/mL
For compound 4 the middle estimate is 3.4-fold (0.53 log units) above the measured one, and the stated range ends above it.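

In this assay, the chloro change gives a 4.2-fold lower number from compound 2 to compound 4 (0.62 log units; beyond the scatter), so on the core of compound 2 it has a larger effect than on the core of compound 3, and the size of the step did not carry across: the same change on two cores in this assay, a 1.3-fold lower number (0.12 log units; within the scatter) from compound 3 to compound 1 and a 4.2-fold lower number (0.62 log units; beyond the scatter) from compound 2 to compound 4, 3.2-fold (0.50 log units) apart, beyond the scatter of two such steps.
The exchange on the sulfur, seen as a 6.1-fold lower number from compound 1 to compound 4 (0.78 log units; beyond the scatter), likewise depends on whether chloro is present: the same change on two cores in this assay, a 1.9-fold higher number (0.28 log units; within the scatter) from compound 2 to compound 3 and a 6.1-fold higher number (0.78 log units; beyond the scatter) from compound 4 to compound 1, 3.2-fold (0.50 log units) apart, beyond the scatter of two such steps.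
These four compounds show that the two changes do not combine independently here, but they do not show why, nor whether this holds elsewhere in the series.

On these data alone, it remains open whether a bromo or methoxy group in place of chloro would also differ between the two cores. The same question stands for a carboxylic acid or an amine on the sulfur side chain.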